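A few compounds are considered here, and "the series" means these few. Any claim that something is new, unique, unknown or untested is made for them only; others in the source may bear on it.

Within the data shown here, compound 3, `Cc1cccc(-c2cnc(C(=O)CCCCCCc3ccccc3)o2)n1`, gives 3.3 nM in an assay (Rattus norvegicus) for inhibition of Fatty-acid amide hydrolase 1 (Homo sapiens) (on this read-out higher numbers stand for weaker inhibition and lower numbers for stronger inhibition), the lowest of the three numbers measured so far. Compound 2, `NC(=O)c1ccc(-c2cnc(C(=O)CCCCCCc3ccccc3)o2)cc1`, gives 10 nM, and compound 1, `O=C(CCCCCCc1ccccc1)c1ncc(-c2ccccc2F)o1`, gives 110 nM. The two steps that lead to compound 3 were both large: a 33-fold lower number from compound 1 to compound 3 (1.52 log units; beyond the scatter), and the smaller but still clear a 3.0-fold lower number from compound 2 to compound 3 (0.48 log units; beyond the scatter). All three compounds share the same core and differ only in the aromatic group attached to it.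

Compound 4, `O=C(CCCCCCc1ccccc1)c1ncc(-c2ncccc2C(=O)O)o1`, changes that same group once more: 3-carboxypyridin-2-yl in place of 6-methylpyridin-2-yl on an aromatic carbon. Among the measured compounds shown here, the nearest precedent is the step between compound 2 and compound 3, where a group carrying a hydrogen-bond donor and acceptor in place of the methyl-bearing pyridine gave a modest rise in the number. The carboxy group in compound 4 brings a similar donor and acceptor count, so a step in the same direction, of modest size, is expected: a 9.1-fold higher number from compound 3 to compound 4 (0.96 log units; beyond the scatter). For compound 4 the expected value is therefore 30 nM, with a plausible range from 6 nM to 200 nM.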

Compound 4, inhibition constant: > 50 nM
Compound 4: no number, only a limit (the forecaster's own chance of this, stated with the estimate: 5%); at least 1.6-fold (0.22 log units) between middle value and limit.
By their numbers in this assay, from the lowest: compound 3; then compound 2; then compound 1.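

Compound 4 gives no number in this assay, only a limit, > 50 nM. Even so, two steps can be read from that limit, an at least 15-fold higher number from compound 3 to compound 4 (1.18 log units; beyond the scatter) and an at least 5.0-fold higher number from compound 2 to compound 4 (0.69 log units; beyond the scatter), which shows that the aromatic carbon next to the ring oxygen does not keep a low number for every pyridine: compound 3 and compound 4 both carry a six-membered aromatic ring with 1 hetero atom, yet their numbers lie far apart. The step between compound 1 and compound 4 cannot be read, so the limit does not place these two in order.

The names 6-methylpyridin-2-yl and 3-carboxypyridin-2-yl differ both in the group on the pyridine and in where it sits, and the compounds shown do not separate these two changes. A methyl ester or a primary amide in place of the carboxylic acid would show whether the acid itself matters.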